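Morpholine in place of pyrrolidine on a thiocarbonyl carbon

A few compounds are considered here, and "the series" means these few. Any claim that something is new, unique, unknown or untested is made for them only; others in the source may bear on it.

Compound 1, `O=c1cc(CSC(=S)N2CCCC2)oc2ccccc12`, in a functional assay on MDA-MB-435S cells (Homo sapiens) for antiproliferative activity, read by MTT assay, with a stated time of 72 h (on this read-out higher numbers stand for weaker inhibition and lower numbers for stronger inhibition), gives > 30000 nM, a limit of the assay.
Compound 2, `O=c1cc(CSC(=S)N2CCCC2)oc2cc(Cl)ccc12`, in this assay gives > 25000 nM, also a limit.

Compound 1 therefore stands at the limit of > 30000 nM in this assay, at which 1 of the 2 values shown sits, with no number of its own. Going by the values given here, the only measured step, a step that the two limits leave unreadable from compound 1 to compound 2, cannot be sized for that reason. Compound 3, `O=c1cc(CSC(=S)N2CCOCC2)oc2ccccc12`, differs from compound 1 by morpholin-4-yl in place of pyrrolidin-1-yl on a thiocarbonyl carbon. Among the compounds with values here, no measured step touches this change, so the expectation rests on compound 1 alone. Compound 3 is expected to stay near the limit, giving an estimated 40000 nM, ranging from 10000 nM to 160000 nM, a step that the limit leaves unreadable from compound 1 to compound 3 that is expected to be within the scatter.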

Compound 3, half-maximal inhibitory concentration: 22200 nM
For compound 3 the middle estimate is 1.8-fold (0.26 log units) above the measured one; low and high end bracket the measured number.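

In this assay, going by these compounds alone, compound 3 gives 22200 nM, the first value in this set that is a number and not a limit, so swapping pyrrolidin-1-yl for morpholin-4-yl on the thiocarbonyl carbon can now be partly sized. The change amounts to an at least 1.3-fold lower number from compound 1 to compound 3 (0.13 log units; that floor lies within the scatter), so it may be small or larger. Only a minimum can be stated for compound 1, which has a limit and no number of its own: the limit of > 30000 nM in this assay, at which 1 of the 3 values shown sits.

The compounds shown leave open how a piperazine or a simple dimethylamino group would behave at this place. They also leave open what a chloro group on the shared core would do alongside morpholin-4-yl.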